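This account rests on a few compounds, and the source may have more. Where it says the series, first, only, none or still open, it means among the compounds named here.

Measured so far in a functional assay on Ishikawa cells (Homo sapiens) for antiproliferative activity, read by CCK-8 assay, with a stated time of 48 h; a lower number here means a stronger inhibitor, a higher number a weaker inhibitor:
compound 1, `C/C=C/C(=O)N1CC(Oc2ccc(Oc3c(-c4ccc(F)cc4)sc4cc(O)ccc34)cc2)C1`, compound 1 gives 9400 nM
compound 2, `O=C(/C=C/CNCCOc1ccc(Oc2c(-c3ccc(F)cc3)sc3cc(O)ccc23)cc1)N1CCC1`, compound 2 gives 6560 nM
compound 3, `CN(C)C(=O)/C=C/CN1CC(Oc2ccc(Oc3c(-c4ccc(F)cc4)sc4cc(O)ccc34)cc2)C1`, compound 3 gives 11200 nM

Compound 1 holds the second highest of the three numbers. Its nearest neighbour is compound 3, with a 1.2-fold higher number from compound 1 to compound 3 (0.08 log units; within the scatter); the furthest is compound 2, with a 1.4-fold lower number from compound 1 to compound 2 (0.16 log units; within the scatter). The remaining pair is no different, a 1.7-fold higher number from compound 2 to compound 3 (0.23 log units; within the scatter), so none of the three can be ordered against the others.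

Compound 4, `C=CC(=O)N1CC(Oc2ccc(Oc3c(-c4ccc(F)cc4)sc4cc(O)ccc34)cc2)C1`, differs from compound 1 in one place: vinyl in place of prop-1-en-1-yl on a carbonyl carbon. For the measured compounds named here, no measured step touches this position. The steps recorded so far alter the linker between the aromatic oxygen and the ring nitrogen, or the group on that nitrogen, and all of them stay within the scatter. They say only that this end of the molecule has so far been tolerant of rearrangement, and nothing directly about trimming the chain on the carbonyl carbon. The change from prop-1-en-1-yl to vinyl is smaller than any of the recorded ones. The expectation is therefore no step beyond the scatter, a 1.3-fold lower number from compound 1 to compound 4 (0.10 log units; within the scatter). For compound 4 the estimated value in this assay is 7500 nM, expected to fall between 3000 nM and 19000 nM.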

Compound 4, half-maximal inhibitory concentration: 12300 nM
Compound 4: middle estimate off by 1.6-fold (0.21 log units), on the low side; the measured number falls inside the stated range.
By their numbers in this assay, from the lowest: compounds 2, 1, 3 and 4 (each within the scatter of the next).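

In this assay, for the compounds shown here, vinyl in place of prop-1-en-1-yl on a carbonyl carbon gives a 1.3-fold higher number from compound 1 to compound 4 (0.12 log units; within the scatter), so this is the first reading at this position, and the two chains cannot be told apart. Compound 4 also stays level with the compounds that carry a different group on the ring nitrogen or a different linker, at a 1.1-fold higher number from compound 3 to compound 4 (0.04 log units; within the scatter) and a 1.9-fold higher number from compound 2 to compound 4 (0.27 log units; within the scatter), and even this last gap, the widest among the four compounds, remains within the scatter. The series therefore shows no separation at either end of this part of the molecule in this assay, and no measurement is available that bears on an explanation of these values.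

On these data alone, whether the carbonyl carbon tolerates more than this small trim remains open: a longer chain, a dimethylaminomethyl-bearing alkene or a saturated ethyl group there could still produce a step beyond the scatter. As far as these compounds go, the four compounds also share the fluorophenyl group and the hydroxyl group on the core, so what an amine or a carboxylic acid in place of that hydroxyl would do is unknown.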